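A few compounds are considered here, and "the series" means these few. Any claim that something is new, unique, unknown or untested is made for them only; others in the source may bear on it.

Measured in a functional assay on HCT-116 cells (Homo sapiens) for antiproliferative activity, read by sulforhodamine B assay, with a stated time of 4 days; on this read-out higher numbers stand for weaker inhibition of growth and lower numbers for stronger inhibition of growth:
Compound 1 `COc1cc(Cl)c(-c2nc(SCC(=O)NC3CC3)nc3[nH]cc(C#N)c23)cc1OC`: 60 nM
Compound 2 `COc1cc(Cl)c(-c2nc(SCC(=O)NC3CC3)nc3[nH]cc(C#N)c23)cc1O`: 1160 nM

Of these two, compound 1 has the lower number and so shows the stronger inhibition of growth. Compound 3 `CNC(=O)CSc1nc(-c2cc(OC)c(OC)cc2Cl)c2c(C#N)c[nH]c2n1` keeps the core of compound 1 and differs only at the amide: methyl in place of cyclopropyl on an amide-type nitrogen. Going by the values given here, the only measured step, a 19-fold higher number from compound 1 to compound 2 (1.29 log units; beyond the scatter), is large, but it lies elsewhere in the molecule and not on the amide-type nitrogen. Among the compounds with values here, no measured compound varies the group at that place, so the step offers little guidance here. A modest move towards a higher number is expected in this assay, perhaps no larger than the scatter. For compound 3 the estimate is 120 nM, with an expected range from 40 nM to 400 nM. The expected change is a 2.0-fold higher number from compound 1 to compound 3 (0.30 log units; within the scatter).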

Compound 3, concentration for 50% growth inhibition: 42 nM
The estimate for compound 3 lay 2.9-fold (0.46 log units) above the measured number; the range from low to high includes it.
By their numbers in this assay, from the lowest: compounds 3 and 1 (each within the scatter of the next); then compound 2.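

In this assay, methyl in place of cyclopropyl on the amide-type nitrogen gives a 1.4-fold lower number from compound 1 to compound 3 (0.15 log units; within the scatter), so the two compounds cannot be told apart. At this place, then, the three-membered ring can give way to a single carbon with no change beyond the scatter, unlike the change elsewhere in the molecule, which gave a 19-fold higher number from compound 1 to compound 2 (1.29 log units; beyond the scatter). The data shown offer no evidence that would explain this result.

The compounds shown leave open how this nitrogen would respond to a group other than these two, such as a plain hydrogen, a longer chain such as butyl, or a chain ending in an amine or a carboxylic acid. As far as these compounds go, it also remains open whether methyl and cyclopropyl would stay within the scatter of each other with the hydroxyl of compound 2 in place.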